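The compounds below may be only part of what the source reports. "The series", "measured", "known", "first", "only" and "open" are said of these compounds alone.

The measured compounds, each with its result in an assay on CHO cells for displacement of a labelled ligand from muscarinic acetylcholine receptor M5 (Homo sapiens), read by scintillation counting, with a stated time of 2 h; a higher number here means a weaker inhibitor, a lower number a stronger inhibitor:

compound 1, `O=C(OCCCc1ccccc1)N(c1ccccc1)C1CN2CCC1CC2`, gives 260 nM
compound 2, `O=C(OCCc1ccc(Cl)c(Cl)c1)N(c1ccccc1)C1CN2CCC1CC2`, gives 80 nM
compound 3, `COc1ccc(CCOC(=O)N(c2ccccc2)C2CN3CCC2CC3)cc1`, gives 230 nM

Among these three, compound 3 stands second highest. Its nearest neighbour is compound 1, and that gap, a 1.1-fold lower number from compound 1 to compound 3 (0.05 log units; within the scatter), is within the scatter, so the two cannot be told apart. Its furthest neighbour is compound 2, and the step of a 2.9-fold higher number from compound 2 to compound 3 (0.46 log units; beyond the scatter) is beyond the scatter, as is the related step of a 3.3-fold lower number from compound 1 to compound 2 (0.51 log units; beyond the scatter).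

Compound 4, `COc1ccc(CCOC(=O)N(c2ccccc2)C2CN3CCC2CC3)cc1OC`, has not yet been measured. It differs from compound 3 by methoxy in place of hydrogen on an aromatic carbon. Among the measured compounds shown here, none of the measured steps adds a second group to a ring that already carries one; the only steps available exchange one aryl group for another, and the step of a 1.1-fold lower number from compound 1 to compound 3 (0.05 log units; within the scatter) shows that a single methoxy-bearing ring gave no change beyond the scatter. On that basis the step of a 1.1-fold higher number from compound 3 to compound 4 (0.04 log units; within the scatter) is expected to be small, in either direction or none at all beyond the scatter. Compound 4 is therefore estimated to give 250 nM in this assay, with a range from 100 nM to 600 nM.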

Compound 4, inhibition constant: 3490 nM
The estimate for compound 4 lay 14-fold (1.14 log units) below the measured number, outside the stated range (above it).
By their numbers in this assay, from the lowest: compound 2; then compounds 3 and 1 (each within the scatter of the next); then compound 4.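

In this assay, this aromatic carbon, ortho to a methoxy group and meta to a large group, proves far less tolerant than the earlier aryl exchanges suggested: methoxy in place of hydrogen gives a 15-fold higher number from compound 3 to compound 4 (1.18 log units; beyond the scatter), whereas the only earlier methoxy-bearing ring stayed within the scatter of the benzyl compound (a 1.1-fold lower number from compound 1 to compound 3 (0.05 log units; within the scatter)). Carrying two groups on the ring is not what separates compound 4 from the others, since the 3,4-dichlorophenyl ring of compound 2 gives the lowest number of the set, and exchanging it for 3,4-dimethoxyphenyl gives a 44-fold higher number from compound 2 to compound 4 (1.64 log units; beyond the scatter); the identity of the groups therefore matters here, and the 3,4-dimethoxyphenyl ring also compares poorly with the first compound's chain (a 13-fold higher number from compound 1 to compound 4 (1.13 log units; beyond the scatter)). Nothing available here accounts for the size of this loss.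

The compounds shown leave open whether a lone methoxy at this carbon, as in 3-methoxyphenyl, is enough for the loss or whether it appears only together with the 4-methoxy group. They also leave open whether a hydroxy group or a fluorine atom at the same carbon, or a mixed 3-chloro-4-methoxyphenyl ring, would read like compound 2 or like compound 4.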